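The compounds below may be only part of what the source reports. "The series", "measured", "known", "first", "only" and "open" are said of these compounds alone.

Measured compounds and their values in a functional assay on the whole organism with Rattus norvegicus as the target, read by paw edema, at a dose of 50 mg/kg by the oral route; on this read-out higher numbers stand for more inhibition at the one dose given (going by the name of the read-out) and lower numbers for less inhibition:
compound 1, `COc1ccc(C2=Nn3c(nnc3-c3cc(Cl)cc(Cl)c3Cl)SC2)cc1`: 19.4%
compound 2, `COc1ccc(-c2nn3c(-c4cc(Cl)cc(Cl)c4Cl)nnc3s2)cc1`: 25.8%

Compound 1 stands lowest of the two numbers measured in this assay, but its nearest neighbour, compound 2, lies only a few points higher, and that gap is within the usual scatter of repeated measurements. So on the numbers shown, compound 1 and compound 2 cannot be told apart, and the inhibition in this assay can be called neither higher nor lower for one than for the other.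

The step to compound 3, `CSc1ccc(C2=Nn3c(nnc3-c3cc(Cl)cc(Cl)c3Cl)SC2)cc1`, which has not yet been measured in this assay, is a single change on the shared core of compound 1: methylsulfanyl in place of methoxy on an aromatic carbon.

For the measured compounds named here, no step between two measured compounds reports what this kind of change does in this assay, so there is nothing to lean on beyond the two values. Compound 3 is expected to stay close to where compound 1 stands, with a step of a number 2.6 percentage points higher from compound 1 to compound 3 (within the scatter) that is estimated to fall within the scatter rather than beyond it in either direction. Compound 3 is therefore estimated to give about 22% in this assay, with the expected range running from 8% to 36%.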

Compound 3, a percentage reported as inhibition, in the whole organism at one dose (the size of the read-out at that dose, not a potency): 9.67%
Estimate against measurement, compound 3: 12.3 percentage points above; measured number inside the range.
By their numbers in this assay, from the lowest: compounds 3, 1 and 2 (each within the scatter of the next, the first and the last beyond it).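

For the compounds shown here, the exchange of methoxy for methylsulfanyl on an aromatic carbon, para to a large group, is the first single change that can be read in this assay: the move from 4-methoxyphenyl to 4-(methylsulfanyl)phenyl gives a number 9.7 percentage points lower from compound 1 to compound 3 (within the scatter) and so stays inside the scatter. On this read-out, the oxygen and the sulfur at this position therefore cannot be told apart, and this one change does not show that the position matters. No measured property is available that bears on this result.

The compounds shown leave open whether this position would respond to a group of another kind, such as an amine or a carboxylic acid, or to a longer chain such as ethoxy or butoxy in place of methoxy. They also leave open whether the same exchange would read the same way on the core of compound 2.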